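Taking the bromo group off a weak compound

This account rests on a few compounds, and the source may have more. Where it says the series, first, only, none or still open, it means among the compounds named here.

So far the measured set is small. In a functional assay on A549 cells (Homo sapiens) for cytotoxicity, read by sulforhodamine B assay, with a stated time of 48 h (a higher number here means a weaker inhibitor, a lower number a stronger inhibitor), compound 1 `COc1ccc(/C=C/C(=O)c2ccc(N)c(-c3ccc(F)cc3)c2)cc1O` gives 940 nM as its reading. In the same cell test, compound 3 `COc1ccc(/C=C/C(=O)c2ccc(NC(C)=O)c(-c3ccc(F)cc3)c2)cc1OC` gives 7380 nM as its reading.

Compound 2 `COc1cc(/C=C/C(=O)c2ccc(N)c(-c3ccc(F)cc3)c2)cc(Br)c1O` reads > 50000 nM in this assay and this is a limit of the assay, not a number. On these data alone, it is the only one of the three that stands at this limit, as the limit of > 50000 nM in this assay, at which 1 of the 3 values shown sits, records, so its true position on the scale is unknown.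

Compound 4 `COc1cc(/C=C/C(=O)c2ccc(N)c(-c3ccc(F)cc3)c2)ccc1O` has not yet been measured. It differs from compound 2 in a single place: hydrogen in place of bromo on an aromatic carbon with hydrogen in place of bromo on an aromatic carbon, ortho to a hydroxy group and meta to a methoxy group.

For the measured compounds named here, no measured pair of compounds shows what such a swap does, so any prediction is rough. The best guide is compound 1 at 940 nM with compound 3 at 7380 nM as a second reading. Both of these are real numbers on the scale. In this assay a large move toward stronger inhibition is therefore expected, an estimated at least 16-fold lower number from compound 2 to compound 4 (1.22 log units; beyond the scatter) that would lie beyond the usual scatter.

For compound 4 the expected value is 3000 nM with an estimated range of 600 nM to 20000 nM on this scale.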

Compound 4, half-maximal inhibitory concentration: 12200 nM
Beside the measured number, compound 4's estimate is 4.1-fold (0.61 log units) below it; the measured number falls inside the stated range.
By their numbers in this assay, from the lowest: compound 1; then compounds 3 and 4 (each within the scatter of the next). At a limit, above all of these: compound 2.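

The bromo group was costing activity at this position, ortho to a hydroxy group and meta to a methoxy group. In this assay, hydrogen in place of bromo on an aromatic carbon gives an at least 4.0-fold lower number from compound 2 to compound 4 (0.61 log units; beyond the scatter), and this moves the series from a limit onto the measured scale. Compound 2 has a limit of the assay, not a number, so this step gives only a smallest possible size: the limit of > 50000 nM in this assay, at which 1 of the 4 values shown sits. Taking off the bromo group is still not enough to match the core of compound 1, since 4-hydroxy-3-methoxyphenyl in place of 3-hydroxy-4-methoxyphenyl gives a 13-fold higher number from compound 1 to compound 4 (1.11 log units; beyond the scatter), showing that the arrangement of the hydroxy and methoxy groups on this ring matters too.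

On these data alone, how a chloro or a methyl group on this same carbon would read remains open, and so does the true size of the bromo effect. As far as these compounds go, it is also open whether a bromo group would cost as much on the 3-hydroxy-4-methoxyphenyl ring, and these readings alone do not explain either change.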